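The source may hold more compounds than are shown below. What is called first, only, known or untested is meant among the compounds shown, and "the series" means these compounds.

Three measured compounds share one core. Compound 1 `Cc1cc(Cl)c(NC(=O)N(Cc2ccc(Oc3ccc(F)cc3)cc2)C2CCCCCC2)c(Cl)n1` gives 14 nM in an assay for inhibition of acyl-CoA:cholesterol acyltransferase (Oryctolagus cuniculus), using microsomes; a higher number here means a weaker inhibitor, a lower number a stronger inhibitor. Compound 2 `CSc1cc(C)nc(Cl)c1NC(=O)N(Cc1ccc(Oc2ccc(F)cc2)cc1)C1CCCCCC1` gives 46 nM in this assay, and compound 3 `Cc1cc(S(C)(=O)=O)c(NC(=O)N(Cc2ccc(Oc3ccc(F)cc3)cc2)C2CCCCCC2)c(Cl)n1` gives 30 nM. Among these three numbers compound 3 stands second highest: the difference between compound 2 and compound 3 is a 1.5-fold lower number from compound 2 to compound 3 (0.19 log units; within the scatter), while the difference between compound 1 and compound 3 is a 2.1-fold higher number from compound 1 to compound 3 (0.33 log units; beyond the scatter).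

Compound 4 `Cc1ccc(NC(=O)N(Cc2ccc(Oc3ccc(F)cc3)cc2)C2CCCCCC2)c(Cl)n1` differs from compound 3 by hydrogen in place of methylsulfonyl on an aromatic carbon. Within the data shown here, no measured step puts a hydrogen at this position, so the nearest evidence is indirect: the step of a 2.1-fold higher number from compound 1 to compound 3 (0.33 log units; beyond the scatter) shows that trading chloro for methylsulfonyl raised the number modestly, and the step of a 3.3-fold higher number from compound 1 to compound 2 (0.52 log units; beyond the scatter) shows a similar rise for methylsulfanyl. Removing the methylsulfonyl altogether is therefore expected to undo that modest rise, giving an estimated step of a 1.7-fold lower number from compound 3 to compound 4 (0.22 log units; within the scatter), a lower number but not far beyond the scatter. Compound 4 is accordingly estimated at 18 nM in this assay, expected to fall between 6 nM and 55 nM.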

Compound 4, half-maximal inhibitory concentration: 19 nM
Beside the measured number, compound 4's estimate is 1.1-fold (0.02 log units) below it; the range from low to high includes it.
By their numbers in this assay, from the lowest: compounds 1, 4, 3 and 2 (each within the scatter of the next, the first and the last beyond it).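

In this assay the bare position gives a reference point for this carbon, and the steps of a 1.6-fold lower number from compound 3 to compound 4 (0.20 log units; within the scatter) and a 1.4-fold higher number from compound 1 to compound 4 (0.13 log units; within the scatter) both lie within the scatter, so methylsulfonyl and chloro cannot be told apart from hydrogen here. Methylsulfanyl is the one group that separates from hydrogen, with a 2.4-fold lower number from compound 2 to compound 4 (0.38 log units; beyond the scatter) as the step, so among these compounds a group on this carbon is not needed to keep the number low. Nothing measured here explains why the groups compare as they do.

Still open, as far as these compounds go, is how an amine, a methoxy group or a longer chain such as ethyl would compare with hydrogen on this carbon. From the compounds shown here alone, these compounds also vary only this one position, so whether the same steps hold with other changes elsewhere on the shared core remains unknown.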